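Replacing pyridin-4-yl with 6-chloropyridin-2-yl

The compounds below may be only part of what the source reports. "The series", "measured", "known", "first", "only" and "open" are said of these compounds alone.

Measured in a functional assay (blood) for inhibition, with Homo sapiens as the target; a higher number here means a weaker inhibitor, a lower number a stronger inhibitor:
- compound 1 `CC(C)(C)Sc1c(CC(C)(C)C(=O)O)n(Cc2ccc(Cl)cc2)c2ccc(OCc3cccnc3)cc12`: > 3000 nM, a limit
- compound 2 `CC(C)(C)Sc1c(CC(C)(C)C(=O)O)n(Cc2ccc(Cl)cc2)c2ccc(OCc3ccncc3)cc12`: > 3000 nM, a limit

Compound 2 stands only at a limit, > 3000 nM. Compound 3 `CC(C)(C)Sc1c(CC(C)(C)C(=O)O)n(Cc2ccc(Cl)cc2)c2ccc(OCc3cccc(Cl)n3)cc12` differs from it by this change: 6-chloropyridin-2-yl in place of pyridin-4-yl on a saturated chain carbon bound to an oxygen on an aromatic ring. Among the measured compounds shown here, the one measured step, a step that the two limits leave unreadable from compound 1 to compound 2, has no readable size, and the only evidence is the limit of > 3000 nM in this assay, at which 2 of the 2 values shown sit. For the measured compounds named here, no measured step therefore sizes this change, so the expectation stays loose. In this assay, a modest move towards a stronger inhibitor is expected, and another limit remains quite possible. The expected step is an at least 1.5-fold lower number from compound 2 to compound 3 (0.17 log units; that floor lies within the scatter). Compound 3 is estimated at 2000 nM, with an expected range of 500 nM to 6000 nM.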

Compound 3, half-maximal inhibitory concentration: 410 nM
The estimate for compound 3 lay 4.9-fold (0.69 log units) above the measured number; the measured number lies below the stated range.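

In this assay, on a saturated chain carbon bound to an oxygen on an aromatic ring, 6-chloropyridin-2-yl in place of pyridin-4-yl gives an at least 7.3-fold lower number from compound 2 to compound 3 (0.86 log units; beyond the scatter). In place of pyridin-3-yl, it gives an at least 7.3-fold lower number from compound 1 to compound 3 (0.86 log units; beyond the scatter). Compound 3 alone carries a number rather than a limit, and the step between the other two cannot be read: the limit of > 3000 nM in this assay, at which 2 of the 3 values shown sit.

Still open, on these data alone, is whether the chlorine or the change to a pyridin-2-yl ring carries this gain. Plain pyridin-2-yl and 6-methylpyridin-2-yl would separate the two.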